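The source may hold more compounds than are shown below. What is called first, only, known or untested is meant among the compounds shown, and "the series" means these compounds.

Of the compounds shown here, three built on one shared core have been measured in an assay on HEK293 cells for displacement of a labelled ligand from adenosine receptor A2b (Homo sapiens); a lower number here means a stronger inhibitor, a higher number a weaker inhibitor. Compound 1 `CCn1c(=O)c2c(nc(Cc3ccccc3)n2C)n(Cc2ccco2)c1=O` gives 12.9 nM. Compound 2 `C=CCn1c(=O)c2c(nc(Cc3c(F)cccc3F)n2C)n(Cc2ccco2)c1=O` gives 21.4 nM. Compound 3 `COCCn1c(=O)c2c(nc(Cc3ccccc3)n2C)n(Cc2ccco2)c1=O` gives 61.7 nM, the highest of the three numbers, so it stands as the weakest inhibitor of the set. Within the data shown here, the only comparison that changes a single point is a 4.8-fold higher number from compound 1 to compound 3 (0.68 log units; beyond the scatter), a methoxy in place of hydrogen on a saturated chain carbon, two bonds along the chain from an aromatic nitrogen.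

Compound 4 `COCCn1c(=O)c2c(nc(Cc3c(F)cccc3F)n2C)n(Cc2ccco2)c1=O` has not yet been measured. It differs from compound 3 by 2,6-difluorophenyl in place of phenyl on a saturated chain carbon bound to an aromatic carbon. Among the measured compounds shown here, no measured pair isolates this change: compound 1, with 12.9 nM, and compound 2, with 21.4 nM, differ both in this group and in the group on the chain carbon, and their two numbers lie within the usual scatter of each other. With nothing firm to lean on, the step expected here is a 1.2-fold lower number from compound 3 to compound 4 (0.09 log units; within the scatter), a change not expected to reach beyond the scatter in either direction. For compound 4 the estimate in this assay is 50 nM, with an expected range from 20 nM to 130 nM.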

Compound 4, inhibition constant: 38.9 nM
For compound 4 the middle estimate is 1.3-fold (0.11 log units) above the measured one, within the range that was stated.
By their numbers in this assay, from the lowest: compounds 1, 2, 4 and 3 (each within the scatter of the next, the first and the last beyond it).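

In this assay, among these compounds, this is the first pair that isolates benzyl to 2,6-difluorobenzyl, and a 1.6-fold lower number from compound 3 to compound 4 (0.20 log units; within the scatter) places the swap within the scatter, so this one pair shows no clear effect of adding the two fluorines at this position. The second new pair tests the other variable site while keeping the 2,6-difluorophenyl group fixed: with methoxymethyl in place of vinyl on a saturated chain carbon bound to an aromatic nitrogen, there is a 1.8-fold higher number from compound 2 to compound 4 (0.26 log units; within the scatter), which also stays within the scatter. Nothing measured here explains either result, and no independent data bear on them.

Among the compounds shown here, each of these conclusions rests on a single pair, so it remains open whether the swap to 2,6-difluorobenzyl would also stay within the scatter with the ethyl or allyl chain of the earlier compounds in place of the methoxy-bearing chain. Also open, as far as these compounds go, is how the number would respond if a single fluorine, a chlorine, an amine or a carboxylic acid stood on the phenyl ring in place of the two fluorines.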